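Removing the chloro from compound 3: an expected value

This account rests on a few compounds, and the source may have more. Where it says the series, first, only, none or still open, it means among the compounds named here.

Measured in a functional assay, tested at 400 ug/mL; on this read-out higher numbers stand for a stronger effect at the one concentration tested and lower numbers for a weaker effect:
compound 1, `Cc1ccc(C2C(C#N)=C(N)OC(c3c[nH]c4ccccc34)=C2C#N)cc1`: 8.5%
compound 2, `COc1ccc(C2C(C#N)=C(N)OC(c3c[nH]c4ccccc34)=C2C#N)cc1`: 28.7%
compound 3, `N#CC1=C(N)OC(c2c[nH]c3ccccc23)=C(C#N)C1c1ccccc1Cl`: 21.4%

Compound 3 stands second highest of the three. Two steps end at compound 3: a number 7.3 percentage points lower from compound 2 to compound 3 (within the scatter), within the scatter, and a number 12.9 percentage points higher from compound 1 to compound 3 (beyond the scatter), beyond it. Compound 4, `N#CC1=C(N)OC(c2c[nH]c3ccccc23)=C(C#N)C1c1ccccc1`, differs from compound 3 by hydrogen in place of chloro on an aromatic carbon. Among the measured compounds shown here, no measured step removes a substituent outright; the steps that bear on it all alter the aryl group, namely a number 20.2 percentage points higher from compound 1 to compound 2 (beyond the scatter) and the two just named, and none is large. The expected step is a number 6.4 percentage points lower from compound 3 to compound 4 (within the scatter), small and downward or none beyond the scatter. For compound 4 the estimate is 15%, with a range from 5% to 30%.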

Compound 4, a percentage reported as activity, at one concentration (the size of the read-out at that concentration, not a potency): 26.7%
Compound 4: the middle estimate sits 11.7 percentage points below what was measured, and the stated range covers the measured number.
By their numbers in this assay, from the lowest: compound 1; then compounds 3, 4 and 2 (each within the scatter of the next).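

Among the compounds shown here, with hydrogen on the aryl ring, this assay gives this position an unsubstituted reference for the first time: a number 5.3 percentage points higher from compound 3 to compound 4 (within the scatter) and a number 2 percentage points lower from compound 2 to compound 4 (within the scatter) show that neither chloro nor methoxy stands apart from hydrogen beyond the scatter. Only the methyl group does, as a number 18.2 percentage points higher from compound 1 to compound 4 (beyond the scatter) shows. Nothing available explains why methyl alone stands apart. On these data alone, whether an amine or a carboxylic acid on this ring would stand apart from hydrogen remains open, as does whether moving the chloro elsewhere on the ring would change the read-out.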